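This account rests on a few compounds, and the source may have more. Where it says the series, first, only, none or still open, it means among the compounds named here.

Measured so far in a functional assay on PC-3 cells (Homo sapiens) for antiproliferative activity, read by MTT assay, tested at 5 uM; on this read-out lower numbers stand for a weaker effect and higher numbers for a stronger effect at the one concentration tested:

Compound 1, `COc1cc(C(=O)N/N=C/c2cccc(F)c2)cc(OC)c1OC`: compound 1 gives 64.1%
Compound 2, `COc1cc(C(=O)N/N=C/c2ccc(C(F)(F)F)cc2)cc(OC)c1OC`: compound 2 gives 61.6%
Compound 3, `COc1cc(C(=O)N/N=C/c2c(Cl)cccc2Cl)cc(OC)c1OC`: compound 3 gives 52.1%

All three share the same core and differ only in the aromatic ring attached to the carbon with a double bond to nitrogen. Compound 3 has the lowest of the three numbers in this assay; compound 2 lies within the scatter of it, while compound 1 sits beyond the scatter above it, the step being a number 12 percentage points lower from compound 1 to compound 3 (beyond the scatter).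

Compound 4, `COc1cc(C(=O)N/N=C/c2ccc(F)cc2)cc(OC)c1OC`, has not yet been measured. Compared with compound 3 the change is 4-fluorophenyl in place of 2,6-dichlorophenyl on a carbon with a double bond to nitrogen. For the measured compounds named here, the only measured step that bears on this is the one from compound 1 to compound 3, where a fluorophenyl ring was replaced by the 2,6-dichlorophenyl ring and the number fell modestly. Compound 4 undoes that replacement, though with the fluorine at a different position of the ring, so a modest rise back toward the values of compound 1 and compound 2 is expected. This means an expected step of a number 9.9 percentage points higher from compound 3 to compound 4 (within the scatter). Compound 4 is therefore estimated to give 62%, within a range from 50% to 73%.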

Compound 4, a percentage reported as inhibition, at one concentration (the size of the read-out at that concentration, not a potency): 82.8%
Estimate against measurement, compound 4: 20.8 percentage points below, outside the stated range (above it).
By their numbers in this assay, from the lowest: compounds 3, 2 and 1 (each within the scatter of the next, the first and the last beyond it); then compound 4.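

For the compounds shown here, the ring on the carbon with a double bond to nitrogen carries more weight in this assay than the earlier compounds showed: there is a number 30.7 percentage points higher from compound 3 to compound 4 (beyond the scatter) as a large step, whereas the only earlier step was modest. Where the fluorine sits also counts, since 4-fluorophenyl in place of 3-fluorophenyl gives a number 18.7 percentage points higher from compound 1 to compound 4 (beyond the scatter) even though the ring keeps the same atoms. Fluoro in place of trifluoromethyl on an aromatic carbon gives a number 21.2 percentage points higher from compound 2 to compound 4 (beyond the scatter) and so leaves compound 4 the strongest of the four, beyond the scatter of each other compound.

Nothing available explains why these changes shift the number as they do. Also open, on these data alone, is whether an amine or a carboxylic acid in place of the fluoro would keep the number this high.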